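The source may report more compounds than this note shows. Statements on the series, on what has been measured and on what is new or still open speak of the compounds shown alone.

Measured so far in a functional assay on MCF7 cells (Homo sapiens) for antiproliferative activity, read by MTT assay, with a stated time of 72 h; a lower number here means a stronger inhibitor, a higher number a weaker inhibitor:
- Compound 1 `CCN(CC)CCCOc1cc2ncnc(Nc3ccc(C#N)cc3)c2cc1OC`: > 100000 nM (a limit)
- Compound 2 `COc1cc2c(Nc3ccc(C#N)cc3)ncnc2cc1OCCCN1CCC(O)CC1`: > 100000 nM (a limit)
- Compound 3 `COc1cc2c(Nc3ccc(C#N)cc3)ncnc2cc1OCCCN1CCC(CO)CC1`: 35100 nM

Compound 3 is the only one of the three with a number, and it is the most active of them. The next change is to compound 4 `COc1cc2c(Nc3ccc(C#N)cc3)ncnc2cc1OCCCN1CCC(N(C)C)CC1`, with dimethylamino in place of hydroxymethyl on a saturated ring carbon.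

The closest measured change sits on the same ring carbon: an at least 2.8-fold lower number from compound 2 to compound 3 (0.45 log units; beyond the scatter). The exchange of the whole amine gives an at least 2.8-fold lower number from compound 1 to compound 3 (0.45 log units; beyond the scatter), while a step that the two limits leave unreadable from compound 1 to compound 2. Both readable steps give only a minimum size, and neither involves dimethylamino, so neither sets a size for this change. The series also sits largely at the limit of > 100000 nM in this assay, at which 2 of the 3 values shown sit.

With so little to go on, only a slight weakening is expected in this assay, not one beyond the scatter. The expected step is a 1.4-fold higher number from compound 3 to compound 4 (0.15 log units; within the scatter). Compound 4 is estimated at 50000 nM, with an expected range of 15000 nM to 100000 nM.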

Compound 4, half-maximal inhibitory concentration: 31000 nM
Compound 4: middle estimate off by 1.6-fold (0.21 log units), on the high side; low and high end bracket the measured number.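

In this assay, the saturated ring carbon three ring bonds from the ring nitrogen accepts dimethylamino as readily as hydroxymethyl: a 1.1-fold lower number from compound 3 to compound 4 (0.05 log units; within the scatter). A hydrogen-bond donor on the substituent is therefore not required at this position to keep the level of compound 3, since dimethylamino has none. Dimethylamino also gives a readable number where hydroxy and diethylamino do not, with an at least 3.2-fold lower number from compound 2 to compound 4 (0.50 log units; beyond the scatter) and an at least 3.2-fold lower number from compound 1 to compound 4 (0.50 log units; beyond the scatter), though both steps start from a limit of the assay and give only a minimum size: the limit of > 100000 nM in this assay, at which 2 of the 4 values shown sit.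

As far as these compounds go, whether a primary amine or a carboxylic acid on this ring carbon would depart from the level shared by compound 3 and compound 4 remains open. Also open, from the compounds shown here alone, is whether any change to the substituent on this ring carbon can give a much lower number, or whether that takes a change elsewhere, such as a longer chain to the ring nitrogen.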